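A few compounds are considered here, and "the series" means these few. Any claim that something is new, unique, unknown or untested is made for them only; others in the source may bear on it.

Compound 1, `Cc1ccc(C2CNC(=O)N2S(=O)(=O)c2ccccc2)cc1`: in a functional assay on A549 cells (Homo sapiens) for cytotoxicity (a higher number here means a weaker inhibitor, a lower number a stronger inhibitor), compound 1 gives 157000 nM.
Compound 2, `Cc1ccc(C2CNC(=O)N2S(=O)(=O)c2ccc(Cl)cc2)cc1`: in this assay compound 2 gives 266000 nM.
Compound 3, `O=C1NCC(c2ccc(Br)cc2)N1S(=O)(=O)c1ccc2c(c1)CCC2`: in this assay compound 3 gives only a limit, > 237000 nM.

Where compound 2 stands is quickly told. Among the measured compounds shown here, only two plain numbers exist in this assay, those of compound 1 and compound 2, and they cannot be told apart: the step of a 1.7-fold higher number from compound 1 to compound 2 (0.23 log units; within the scatter) lies within the scatter. The third value, that of compound 3, is a limit and not a number, (the limit of > 237000 nM in this assay, at which 1 of the 3 values shown sits), so it offers no point of comparison.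

Compound 4, `O=C1NCC(c2ccc(Br)cc2)N1S(=O)(=O)c1ccc(Cl)cc1`, differs from compound 2 in one place: bromo in place of methyl on an aromatic carbon. For the measured compounds named here, no measured pair here shows a bromo in place of a methyl; the only measured step, from compound 1 to compound 2, concerns a chloro in place of hydrogen and stayed within the scatter. With nothing to suggest otherwise, the expectation for compound 4 in this assay is a step of a 1.1-fold lower number from compound 2 to compound 4 (0.03 log units; within the scatter), that is, no movement beyond the scatter. Compound 4 is therefore estimated at 250000 nM, with a range from 100000 nM to 600000 nM.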

Compound 4, half-maximal inhibitory concentration: 84000 nM
The estimate for compound 4 lay 3.0-fold (0.47 log units) above the measured number; measured number outside the range, below it.
By their numbers in this assay, from the lowest: compounds 4, 1 and 2 (each within the scatter of the next, the first and the last beyond it).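

In this assay, among the compounds shown here, the change of 4-methylphenyl to 4-bromophenyl gives a 3.2-fold lower number from compound 2 to compound 4 (0.50 log units; beyond the scatter), a modest move, but the first in this set to pass the scatter; the only earlier step, a 1.7-fold higher number from compound 1 to compound 2 (0.23 log units; within the scatter), did not. This shows that the number responds to the group on an aromatic carbon of a six-membered aromatic ring of carbon only, para to a large group, even when one heavy atom replaces one heavy atom and neither group has hydrogen-bond donors, hydrogen-bond acceptors or a net charge. Compound 3 also carries the 4-bromophenyl group, but its value is a limit and cannot confirm the shift on a second background: the limit of > 237000 nM in this assay, at which 1 of the 4 values shown sits.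

From the compounds shown here alone, it remains open whether the lower number belongs to bromo specifically or would also appear with chloro, methoxy, an amine or a carboxylic acid at this position. For the compounds shown here, it is also open whether the same exchange would shift the number on the unsubstituted benzenesulfonyl background of compound 1, since this single pair gives the only readable comparison at this position.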